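Trading the 4-methylphenoxy end of compound 3 for ethyl

The source may hold more compounds than are shown below. What is called first, only, known or untested is meant among the compounds shown, and "the series" means these compounds.

Within the data shown here, in a functional assay on PC-3 cells (Homo sapiens) for antiproliferative activity, read by MTT assay, with a stated time of 48 h (a lower number here means a stronger inhibitor of growth, a higher number a weaker inhibitor of growth), compound 3 `Cc1ccc(OCCCCN(Cc2ccc(C(=O)NO)cc2)c2ncc(-c3ccc(C)cc3)s2)cc1` gives 1220 nM, the lowest of the three numbers so far. Compound 1 `CCCCCN(Cc1ccc(C(=O)NO)cc1)c1ncc(-c2ccc(C)cc2)s1` gives 5060 nM, and compound 2 `Cc1ccc(-c2cnc(N(Cc3ccccc3)Cc3ccc(C(=O)NO)cc3)s2)cc1` gives 10400 nM. The next to be tested is compound 4 `CCCCCCN(Cc1ccc(C(=O)NO)cc1)c1ncc(-c2ccc(C)cc2)s1`, which differs from compound 3 as follows: ethyl in place of 4-methylphenoxy on a saturated chain carbon, four bonds along the chain from a nitrogen on an aromatic ring. This puts ethyl in place of 4-methylphenoxy on a saturated chain carbon, four bonds along the chain from a nitrogen on an aromatic ring. The nearest guide is 4-methylphenoxy in place of methyl at that same place, which gave a 4.1-fold lower number from compound 1 to compound 3 (0.62 log units; beyond the scatter). Ethyl is not methyl, however, and no measured step covers that difference. The larger 8.5-fold lower number from compound 2 to compound 3 (0.93 log units; beyond the scatter) and the smaller 2.1-fold higher number from compound 1 to compound 2 (0.31 log units; beyond the scatter) both involve a phenyl change on the carbon bound to the nitrogen, so they bear on it less directly. In this assay, a modest rise is therefore expected, running the nearest guide in reverse: the estimated change is a 3.3-fold higher number from compound 3 to compound 4 (0.52 log units; beyond the scatter). The estimate for compound 4 is 4000 nM, with an expected range of 1900 nM to 8500 nM.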

Compound 4, concentration for 50% growth inhibition: 5270 nM
Beside the measured number, compound 4's estimate is 1.3-fold (0.12 log units) below it; the range from low to high includes it.
By their numbers in this assay, from the lowest: compound 3; then compounds 1, 4 and 2 (each within the scatter of the next, the first and the last beyond it).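

In this assay, the swap of the 4-methylphenoxy end for ethyl (a 4.3-fold higher number from compound 3 to compound 4 (0.64 log units; beyond the scatter)) shows that the lower number of compound 3 depends on that end group, as a simple alkyl end on the same chain does not retain it. One methyl more at the end of the chain (a 1.0-fold higher number from compound 1 to compound 4 (0.02 log units; within the scatter)) stays within the scatter, so among these alkyl chains, this added carbon does not reproduce what 4-methylphenoxy gives. Pentyl in place of phenyl on the carbon bound to the nitrogen (a 2.0-fold lower number from compound 2 to compound 4 (0.30 log units; within the scatter)) also stays within the scatter, leaving compound 3 as the only one set apart here.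

Nothing at hand accounts for the gap between the 4-methylphenoxy and ethyl ends. As far as these compounds go, it remains open whether a plain phenoxy, an amine or a carboxylic acid at the chain end would keep the number of compound 3.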